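A few compounds are considered here, and "the series" means these few. Any claim that something is new, unique, unknown or untested is made for them only; others in the source may bear on it.

In an ADME assay on the whole organism (Mus musculus, strain CD-1) for pharmacokinetics, with a stated time of 6 h, at a dose of 10 mg/kg by the oral route (on this read-out lower numbers stand for lower exposure and higher numbers for higher exposure at the dose given), compound 3 `Cc1c(C(=O)N2CC[C@H](N)C2)nc(-c2ccc(C#N)c(F)c2)n1-c1ccc2nn(C)cc2c1` gives 80 ng.h/mL, within the scatter of compound 2 `Cc1c(C(=O)N2CCC[C@@H](N)C2)nc(-c2ccc(C#N)c(F)c2)n1-c1ccc2c(cnn2C)c1` at 106 ng.h/mL. Both lie above compound 1 `Cc1c(C(=O)N2CCC[C@@H](N)C2)nc(-c2ccc(C#N)c(F)c2)n1-c1ccc2nn(C)cc2c1` at 25 ng.h/mL. Compound 4 `Cc1c(C(=O)N2CC[C@H](N(C)C)C2)nc(-c2ccc(C#N)c(F)c2)n1-c1ccc2nn(C)cc2c1` differs from compound 3 in one group: dimethylamino in place of amino on a saturated ring carbon.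

Within the data shown here, no measured pair covers this exact change. The closest evidence concerns the same amine-bearing ring: 3-aminopyrrolidin-1-yl in place of 3-aminopiperidin-1-yl gave a 3.2-fold higher number from compound 1 to compound 3 (0.51 log units; beyond the scatter). The other measured change, 1-methyl-1H-indazol-5-yl in place of 2-methyl-2H-indazol-5-yl, gave a 4.2-fold higher number from compound 1 to compound 2 (0.63 log units; beyond the scatter). Both steps are modest, and neither indicates a direction for the new change. In this assay, no step beyond the scatter is therefore expected, though a modest step of either sign remains possible. The expected step is a 1.3-fold higher number from compound 3 to compound 4 (0.10 log units; within the scatter). Compound 4 is estimated at 100 ng.h/mL, with an expected range of 35 ng.h/mL to 300 ng.h/mL.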

Compound 4, area under the concentration-time curve: 760 ng.h/mL
Compound 4: middle estimate off by 7.6-fold (0.88 log units), on the low side, outside the stated range (above it).
By their numbers in this assay, from the lowest: compound 1; then compounds 3 and 2 (each within the scatter of the next); then compound 4.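

In this assay, the group on the saturated ring carbon, two ring bonds from the ring nitrogen, proves to be a strong handle: dimethylamino in place of amino gives a 9.5-fold higher number from compound 3 to compound 4 (0.98 log units; beyond the scatter). The earlier compounds shown here all carry an unsubstituted amino group, so they could show effects of the ring and of the indazole methyl position, but not of substitution on this amine. Combined with the change of ring, the new group gives a 30-fold higher number from compound 1 to compound 4 (1.48 log units; beyond the scatter), the only step in this set printed as large.

No measurement shown bears on why the number rises. Methylamino on the same carbon would show whether one added methyl carries part of the step, and 3-(dimethylamino)piperidin-1-yl would show whether it carries over from 3-aminopiperidin-1-yl.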